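Ether replacements for the 4-ethylpiperidin-1-yl group in compound 1

The source may hold more compounds than are shown below. What is called first, only, known or untested is meant among the compounds shown, and "the series" means these compounds.

Measured so far:
compound 1 `CCC1CCN(c2nc(C(C)(C)C)ccc2CNC(=O)C(C)c2ccc(NS(C)(=O)=O)c(F)c2)CC1`: 0.1 nM
compound 2 `CCOc1nc(C(C)(C)C)ccc1CNC(=O)C(C)c1ccc(NS(C)(=O)=O)c(F)c1`: 14.8 nM
compound 3 `CCCOc1nc(C(C)(C)C)ccc1CNC(=O)C(C)c1ccc(NS(C)(=O)=O)c(F)c1`: 1.7 nM

In an assay on cells for antagonist activity at transient receptor potential cation channel subfamily V member 1 (Homo sapiens), read by FLIPR and calcium flux, with a stated time of 6 min (a lower number here means a stronger inhibitor, a higher number a weaker inhibitor), compound 1 stands lowest of the three, with compound 3 nearest and compound 2 furthest. Compound 4 `CCOCCOc1nc(C(C)(C)C)ccc1CNC(=O)C(C)c1ccc(NS(C)(=O)=O)c(F)c1` is not yet measured. Its change from compound 1 is 2-ethoxyethoxy in place of 4-ethylpiperidin-1-yl on an aromatic carbon. Within the data shown here, two measured steps bear on this, both replacing the same group with an oxygen-linked chain: a 150-fold higher number from compound 1 to compound 2 (2.17 log units; beyond the scatter) and a 17-fold higher number from compound 1 to compound 3 (1.23 log units; beyond the scatter). Between them, an 8.7-fold lower number from compound 2 to compound 3 (0.94 log units; beyond the scatter) shows that a longer chain gives a lower number. The 2-ethoxyethoxy chain is longer still but also differs from propoxy in what enters, so the step for compound 4 is expected to be large and upward, a 30-fold higher number from compound 1 to compound 4 (1.48 log units; beyond the scatter). Compound 4 is therefore estimated at 3 nM, in the range 0.7 nM to 15 nM.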

Compound 4, inhibition constant: 23.9 nM
The estimate for compound 4 lay 8.0-fold (0.90 log units) below the measured number; measured number above the stated range.
By their numbers in this assay, from the lowest: compound 1; then compound 3; then compounds 2 and 4 (each within the scatter of the next).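

Chain length alone does not set the number at this position in this assay: with a 14-fold higher number from compound 3 to compound 4 (1.15 log units; beyond the scatter), the 2-ethoxyethoxy chain goes against the fall seen from ethoxy to propoxy. With a 1.6-fold higher number from compound 2 to compound 4 (0.21 log units; within the scatter), the longer chain gains nothing over ethoxy, and a 240-fold higher number from compound 1 to compound 4 (2.38 log units; beyond the scatter) leaves it far from the 4-ethylpiperidin-1-yl group. Nothing available accounts for the loss. Open, going by these compounds, is whether butoxy, a longer all-carbon chain, extends the propoxy gain, and whether unsubstituted piperidine or morpholine stays near compound 1.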